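Second Fluoro on the Aniline Ring of a Benzofuran Amidoxime

This account rests on a few compounds, and the source may have more. Where it says the series, first, only, none or still open, it means among the compounds named here.

Measured so far:
- compound 1 `O/N=C(/Nc1cccc(F)c1)c1ccc2occc2c1`: 32700 nM
- compound 2 `O/N=C(/Nc1cccc(Cl)c1)c1ccc2occc2c1`: 690 nM
- compound 3 `O/N=C(/Nc1cccc(C(F)(F)F)c1)c1ccc2occc2c1`: 1200 nM

Three amidoximes on a shared core were tested in an assay on isolated protein for inhibition of Indoleamine 2,3-dioxygenase 1 (Homo sapiens), read by spectrophotometry; a higher number here means a weaker inhibitor, a lower number a stronger inhibitor. Compound 1 stands highest of the three numbers: in this assay compound 1 gives 32700 nM, and its steps to both neighbours lie beyond the scatter, so it is the weakest inhibitor here. The step of a 47-fold lower number from compound 1 to compound 2 (1.68 log units; beyond the scatter) is large, as is the step of a 27-fold lower number from compound 1 to compound 3 (1.44 log units; beyond the scatter); between compound 2 and compound 3 the step of a 1.7-fold higher number from compound 2 to compound 3 (0.24 log units; within the scatter) stays within the scatter.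

Compound 4 `O/N=C(/Nc1ccc(F)c(F)c1)c1ccc2occc2c1` has not yet been measured. Relative to compound 1 the change is fluoro in place of hydrogen on an aromatic carbon. For the measured compounds named here, no measured step matches this change: the two that bear on it, a 47-fold lower number from compound 1 to compound 2 (1.68 log units; beyond the scatter) and a 27-fold lower number from compound 1 to compound 3 (1.44 log units; beyond the scatter), both replace the fluoro rather than keep it and add a second one, and both point toward a lower number. The fluoro already present in compound 1 is retained in compound 4, so only a modest move is expected. Compound 4 is estimated at 10000 nM, with a range from 3000 nM to 33000 nM. The expected step is a 3.3-fold lower number from compound 1 to compound 4 (0.51 log units; beyond the scatter).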

Compound 4, half-maximal inhibitory concentration: 22700 nM
Estimate against measurement, compound 4: 2.3-fold (0.36 log units) below; the range from low to high includes it.
By their numbers in this assay, from the lowest: compounds 2 and 3 (each within the scatter of the next); then compounds 4 and 1 (each within the scatter of the next).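

In this assay, fluoro in place of hydrogen on the aromatic carbon ortho to a fluoro group and para to a large group gives a 1.4-fold lower number from compound 1 to compound 4 (0.16 log units; within the scatter), so compound 1 and compound 4 cannot be told apart and this position takes a second fluoro without a readable change. For the compounds shown here, the earlier large steps, a 47-fold lower number from compound 1 to compound 2 (1.68 log units; beyond the scatter) and a 27-fold lower number from compound 1 to compound 3 (1.44 log units; beyond the scatter), came from replacing the existing fluoro with chloro or trifluoromethyl, whereas this result is the first to concern a hydrogen on the ring and shows that keeping that fluoro and adding another does not reproduce those steps. Nothing measured here offers an explanation for this result.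

The compounds shown leave open whether a larger group at this same carbon, such as chloro, methoxy or an amine, would also leave the number where it is, or whether fluoro alone does so. They also leave open whether a fluoro at this position would read the same on the chloro-bearing compound 2 or the trifluoromethyl-bearing compound 3, where the number starts much lower.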